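Lengthening the Diamine Chain of Compound 2

The source may hold more compounds than are shown below. What is called first, only, known or untested is meant among the compounds shown, and "the series" means these compounds.

Measured so far:
Compound 1, `COc1cc(/C=C/C(=O)NCCCCC(N)CN)ccc1O`, gives 7.96% in a physicochemical assay, read by spectrophotometry, with a stated time of 10 min, tested at 0.05 mM, in the presence of a further agent that is not named here; a lower number here means a weaker effect, a higher number a stronger effect of the compound at the concentration tested.
Compound 2, `NCC(N)CC(=O)N1CCN(C(=O)CCn2cccc(O)c2=O)CC1`, gives 18.5% in this assay.

Compound 2 stands highest of the two numbers measured. Its nearest neighbour is compound 1, whose number lies lower by a gap that is beyond the usual scatter of this measurement.

Compound 3, `NCC(N)CCC(=O)N1CCN(C(=O)CCn2cccc(O)c2=O)CC1`, has not yet been measured. It differs from compound 2 in a single place: 2,3-diaminopropyl in place of 1,2-diaminoethyl on a saturated chain carbon bound to a carbonyl carbon. Within the data shown here, no pair of measured compounds shows what such a change does, so the expectation rests on compound 2 alone. The change is a small one, with the counted donors and acceptors unchanged, and the expected step from a number 0.5 percentage points lower from compound 2 to compound 3 (within the scatter) in this assay is none beyond the scatter. Compound 3 is therefore expected to give about 18%, with a likely range from 8% to 28%.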

Compound 3, a percentage reported as activity, at one concentration (the size of the read-out at that concentration, not a potency): 23.9%
Beside the measured number, compound 3's estimate is 5.9 percentage points below it; the measured number falls inside the stated range.
By their numbers in this assay, from the lowest: compound 1; then compounds 2 and 3 (each within the scatter of the next).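

Among these compounds, compound 2 and compound 3 form the first measured pair that differs in one place, so this change can now be read directly. In this assay, 2,3-diaminopropyl in place of 1,2-diaminoethyl on a saturated chain carbon bound to a carbonyl carbon gives a number 5.4 percentage points higher from compound 2 to compound 3 (within the scatter) and so does not separate the two compounds. At this position, then, one more chain carbon, with the counted donors and acceptors unchanged, leaves no step beyond the scatter, and no measurement shown here offers an explanation for this result.

Still open, going by these compounds, is whether a longer chain, such as 3,4-diaminobutyl, would also stay within the scatter of compound 3. Also open, on these data alone, is what a hydroxyl or a carboxylic acid would do at this position in place of one of the amines.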